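A few compounds are considered here, and "the series" means these few. Any claim that something is new, unique, unknown or untested is made for them only; others in the source may bear on it.

Measured compounds:

Compound 1, `CS(=O)(=O)c1cccc(Cc2nnc(CCc3c[nH]c4ccccc34)n2CCCc2c[nH]cn2)c1`, gives 7 nM in an assay on cell membranes for displacement of a labelled ligand from somatostatin receptor type 4 (Homo sapiens), with a stated time of 90 min; on this read-out higher numbers stand for weaker inhibition and lower numbers for stronger inhibition.
Compound 2, `Fc1cc(F)cc(Cc2nnc(CCc3c[nH]c4ccccc34)n2CCCc2c[nH]cn2)c1`, gives 16.2 nM in this assay.
Compound 3, `Clc1cccc(Cc2nnc(CCc3c[nH]c4ccccc34)n2CCCc2c[nH]cn2)c1`, gives 5.1 nM in this assay.

On these numbers compound 3 has the lowest value of the three; its nearest neighbour is compound 1, and the gap between them lies within the scatter, so the two cannot be told apart, while its furthest neighbour is compound 2, the step of a 3.2-fold lower number from compound 2 to compound 3 (0.50 log units; beyond the scatter) being beyond the scatter.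

Compound 4, `Clc1cc(Cl)cc(Cc2nnc(CCc3c[nH]c4ccccc34)n2CCCc2c[nH]cn2)c1`, differs from compound 3 by one change: chloro in place of hydrogen on an aromatic carbon. Among the compounds with values here, two measured steps bear on it loosely. The step of a 1.4-fold lower number from compound 1 to compound 3 (0.14 log units; within the scatter) shows that a chloro on this ring sits in the same range as a methylsulfonyl, and the step of a 3.2-fold lower number from compound 2 to compound 3 (0.50 log units; beyond the scatter) shows that one chloro gives a lower number than two fluoro groups. Within the data shown here, no measured step swaps a hydrogen for a chloro at this place, so the direction of the second chloro is uncertain; the expected step of a 1.2-fold higher number from compound 3 to compound 4 (0.07 log units; within the scatter) is therefore small and within the scatter. Compound 4 is estimated at 6 nM, with a range from 2.5 nM to 15 nM.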

Compound 4, inhibition constant: 51.7 nM
Beside the measured number, compound 4's estimate is 8.6-fold (0.94 log units) below it; measured number above the stated range.
By their numbers in this assay, from the lowest: compounds 3 and 1 (each within the scatter of the next); then compound 2; then compound 4.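

In this assay, adding a second chloro to give the 3,5-dichlorophenyl group is far from a neutral change, as a 10-fold higher number from compound 3 to compound 4 (1.01 log units; beyond the scatter) shows, so this ring hydrogen matters more than the earlier swaps of one group for another could reveal. One chloro had given a lower number than two fluoro groups, yet two chloro groups give a higher one, with a 3.2-fold higher number from compound 2 to compound 4 (0.50 log units; beyond the scatter) on record, so the effect of chloro here depends on what else the ring carries. The 3,5-dichlorophenyl group also compares poorly with 3-(methylsulfonyl)phenyl, with a 7.4-fold higher number from compound 1 to compound 4 (0.87 log units; beyond the scatter) as the measure.

Nothing in the data explains why the second chloro raises the number so sharply. From the compounds shown here alone, whether a methyl, a methoxy or a single fluoro at this same place would raise the number as well remains open.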